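This account rests on a few compounds, and the source may have more. Where it says the series, first, only, none or still open, it means among the compounds named here.

Four compounds share one core: a bicyclic amine and a fused pyridine unit joined through a central amine nitrogen that carries a third, variable arm. Compound 1 `NC(=O)NC/C=C\CN(C[C@H]1Cc2ccccc2CN1)[C@H]1CCCc2cccnc21` has an arm ending in a urea, compound 2 `C/C(=C/CN)CN(C[C@H]1Cc2ccccc2CN1)[C@H]1CCCc2cccnc21` a shorter arm ending in a primary amine, and compound 3 `NCC1CC1CN(C[C@H]1Cc2ccccc2CN1)[C@H]1CCCc2cccnc21` an arm in which that amine sits on a three-membered ring. In a functional assay on CCRF-CEM cells for antagonist activity at C-X-C chemokine receptor type 4 (Homo sapiens), read by calcium flux, with stated times of 25 min and 90 s (on this read-out lower numbers stand for stronger inhibition and higher numbers for weaker inhibition), compound 1 gives 210 nM and compound 2 gives 28 nM; the step of a 7.5-fold lower number from compound 1 to compound 2 (0.88 log units; beyond the scatter) shows how much this arm matters. Compound 3 gives 6.4 nM; 13 nM (2 entries) in this assay, the repeated values being (the several entries of compound 3 in this assay, 6.4 nM; 13 nM (2 entries)). Among the compounds with a single number, compound 2 stands lowest, with compound 1 nearest to it.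

Compound 4 `N[C@H]1CC[C@@H](N(C[C@H]2Cc3ccccc3CN2)[C@H]2CCCc3cccnc32)CC1` is not yet measured. It differs from compound 2 by a group of 7 heavy atoms (6 carbon, 1 nitrogen; one six-membered non-aromatic ring of carbon only) in place of a group of 6 heavy atoms (5 carbon, 1 nitrogen; no ring), on an amine nitrogen. Within the data shown here, the only measured step, from compound 1 to compound 2, changed this same arm and moved the number well beyond the scatter, so a change here can be large. The values of compound 3, whose arm also holds a ring, lie below those of compound 2. Compound 4 is therefore expected to give a somewhat lower number in this assay, and the step of a 1.9-fold lower number from compound 2 to compound 4 (0.27 log units; within the scatter) is estimated to fall near or just beyond the scatter. Compound 4 is estimated at 15 nM, between 4 nM and 60 nM.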

Compound 4, half-maximal inhibitory concentration: 1800 nM
Estimate against measurement, compound 4: 120-fold (2.08 log units) below; the whole stated range lies below it.
By their numbers in this assay, from the lowest: compound 2; then compound 1; then compound 4.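

In this assay, replacing the open chain on the amine nitrogen with 4-aminocyclohexyl gives a 64-fold higher number from compound 2 to compound 4 (1.81 log units; beyond the scatter), the largest step seen at this position, even though the two groups have the same hydrogen-bond donor and acceptor counts and are close in heavy-atom count. Keeping an amine at the end of the arm is therefore not enough for a low number, as the urea arm also does better, with an 8.6-fold higher number from compound 1 to compound 4 (0.93 log units; beyond the scatter). A ring in the arm does not by itself decide the outcome either: compound 3, with its three-membered ring, gives 6.4 nM; 13 nM (2 entries), while the six-membered ring of compound 4 gives 1800 nM.

Nothing available here accounts for why this ring change raises the number so sharply. From the compounds shown here alone, it remains open whether a cyclopentyl ring carrying an amine, or a longer saturated chain ending in an amine, on this same amine nitrogen would stay near compound 2 or move towards compound 4.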